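The compounds below may be only part of what the source reports. "The series", "measured", "known", "first", "only" and "open" are said of these compounds alone.

- Compound 1 `COc1cccc2cc(CSc3nc4cncnc4n3[C@@H]3O[C@H](COC(C)=O)[C@@H](O)[C@H]3O)c(=O)oc12` gives 11000 nM
- Compound 2 `CC1(C)O[C@@H]2[C@H](O1)[C@H](n1c(SCc3cc4ccccc4oc3=O)nc3cncnc31)O[C@@H]2CO` gives 8800 nM

In a functional assay on Huh-5-2 cells (Homo sapiens) for cytotoxicity, read by microscopy (on this read-out higher numbers stand for lower toxicity in this test and lower numbers for higher toxicity in this test), compound 2 gives 8800 nM and compound 1 gives 11000 nM in the same test. The two values lie within the usual scatter of each other, so compound 2 stands level with compound 1 on these numbers.

Compound 3 `COc1cccc2cc(CSc3nc4cncnc4n3[C@@H]3O[C@H](CO)[C@@H]4OC(C)(C)O[C@@H]43)c(=O)oc12` has yet to be measured. It is compound 2 with a single change methoxy in place of hydrogen on an aromatic carbon that puts methoxy in place of hydrogen on an aromatic carbon. Going by the values given here, no two measured compounds differ in only one place, so this change has not been observed directly.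

Compound 1, which also carries a methoxy group, gives 11000 nM and remains within the scatter of compound 2. No step beyond the scatter is therefore expected in this assay in either direction. The estimate amounts to a 1.1-fold higher number from compound 2 to compound 3 (0.03 log units; within the scatter) and is expected to stay within the scatter. For compound 3 the estimated value is 9500 nM with an expected range from 4000 nM to 22000 nM in this test.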

Compound 3, half-maximal cytotoxic concentration: 8400 nM
The estimate for compound 3 lay 1.1-fold (0.05 log units) above the measured number; low and high end bracket the measured number.
By their numbers in this assay, from the lowest: compounds 3, 2 and 1 (each within the scatter of the next).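

With methoxy in place of hydrogen on an aromatic carbon, ortho to a fused ring and meta to a fused ring, the change can now be read directly, and in this assay it gives a 1.0-fold lower number from compound 2 to compound 3 (0.02 log units; within the scatter). This position therefore takes the methoxy group with no step beyond the scatter, which compounds 1 and 2 alone could not show because they differ in more than one place. Going by these compounds alone, compound 3 also forms the first one-place pair with compound 1: exchanging one group of 12 heavy atoms on the aromatic nitrogen for another, with 8 carbon and 4 oxygen atoms in place of 7 carbon and 5 oxygen atoms, gives a 1.3-fold lower number from compound 1 to compound 3 (0.12 log units; within the scatter), and this too stays within the scatter. Nothing available here explains these results.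

The compounds shown leave open whether a hydroxy group, an amine or a longer chain such as ethoxy on the same aromatic carbon would move the number beyond the scatter. They also leave open whether a carboxylic acid or an amine on the group at the aromatic nitrogen would do so.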